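Phenyl for Ethyl on the Bromo Analogue

The source may report more compounds than this note shows. Statements on the series, on what has been measured and on what is new or still open speak of the compounds shown alone.

Compound 1, `CCn1c(/N=C/c2ccc(F)cc2)c(C#N)sc1=S`, gives 0.00059 nM in an assay on HEK293 cells for displacement of a labelled ligand from adenosine receptor A1 (Homo sapiens), read by scintillation counting, with a stated time of 60 min; on this read-out higher numbers stand for weaker inhibition and lower numbers for stronger inhibition.
Compound 2, `N#Cc1sc(=S)n(-c2ccccc2)c1/N=C/c1ccc(F)cc1`, gives 0.00063 nM in this assay.
Compound 3, `CCn1c(/N=C/c2ccc(Br)cc2)c(C#N)sc1=S`, gives 0.00074 nM in this assay.

Compound 3 stands at the highest of the three numbers in this assay, yet all three lie close together: compound 2 and compound 3 give values within the scatter of each other, and the step of a 1.3-fold higher number from compound 1 to compound 3 (0.10 log units; within the scatter) is also within the scatter. Compound 4, `N#Cc1sc(=S)n(-c2ccccc2)c1/N=C/c1ccc(Br)cc1`, differs from compound 3 by phenyl in place of ethyl on an aromatic nitrogen. The same exchange was measured once on the fluoro compound, where the step of a 1.1-fold higher number from compound 1 to compound 2 (0.03 log units; within the scatter) was within the scatter. That single step bears on the present one and suggests no movement beyond the scatter in this assay. Accordingly, the step from compound 3 to compound 4 is expected to be a 1.1-fold higher number from compound 3 to compound 4 (0.03 log units; within the scatter). Compound 4 is therefore estimated at 0.0008 nM, with a range from 0.0003 nM to 0.002 nM.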

Compound 4, inhibition constant: 186 nM
For compound 4 the middle estimate is 230000-fold (5.37 log units) below the measured one; the whole stated range lies below it.
By their numbers in this assay, from the lowest: compounds 1, 2 and 3 (each within the scatter of the next); then compound 4.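

Phenyl in place of ethyl on the aromatic nitrogen gives a 250000-fold higher number from compound 3 to compound 4 (5.40 log units; beyond the scatter) in this assay, and bromo in place of fluoro on the aromatic carbon gives a 300000-fold higher number from compound 2 to compound 4 (5.47 log units; beyond the scatter). Each change alone leaves the number within the scatter on the core of compound 1, but together they do not, so the effect at this nitrogen depends on the halogen the compound carries: the same change on two cores in this assay, a 1.1-fold higher number (0.03 log units; within the scatter) from compound 1 to compound 2 and a 250000-fold higher number (5.40 log units; beyond the scatter) from compound 3 to compound 4, 240000-fold (5.37 log units) apart, beyond the scatter of two such steps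
Read from the halogen, the same dependence appears, with the effect of bromo for fluoro set by the group on the nitrogen: the same change on two cores in this assay, a 1.3-fold higher number (0.10 log units; within the scatter) from compound 1 to compound 3 and a 300000-fold higher number (5.47 log units; beyond the scatter) from compound 2 to compound 4, 240000-fold (5.37 log units) apart, beyond the scatter of two such steps

As far as these compounds go, this rests on a single set of four compounds, so it remains open whether the jump belongs only to phenyl paired with bromo. From the compounds shown here alone, how chloro in place of bromo, or benzyl or a propyl chain in place of phenyl, would behave also stays open.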